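Moving the fluorine on the benzyl group: cytotoxicity notes

The source may hold more compounds than are shown below. What is called first, only, known or untested is meant among the compounds shown, and "the series" means these compounds.

Measured in an ADME assay on MT4 cells (Homo sapiens) for cytotoxicity, read by MTT assay, with a stated time of 5 days; a higher number here means that more compound is tolerated, a lower number that less compound is tolerated:
- compound 1, `Cc1cc(C)c(Oc2cc(Nc3ccc(C#N)cc3)ncc2C(=O)NCc2cn(Cc3ccccc3C#N)nn2)c(C)c1`, gives > 219000 nM, a limit of the assay.
- compound 2, `COC(=O)Cn1cc(CNC(=O)c2cnc(Nc3ccc(C#N)cc3)cc2Oc2c(C)cc(C)cc2C)nn1`, gives 13800 nM.
- compound 3, `Cc1cc(C)c(Oc2cc(Nc3ccc(C#N)cc3)ncc2C(=O)NCc2cn(Cc3cccc(F)c3)nn2)c(C)c1`, gives >= 204000 nM, a limit of the assay.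

Compound 3 therefore stands at the upper edge of what this assay reports, at the limit of >= 204000 nM in this assay, at which 1 of the 3 values shown sits. Compound 1 sits at the other edge, (the limit of > 219000 nM in this assay, at which 1 of the 3 values shown sits). Only compound 2 gives a number, and the two steps that involve it are both large: an at least 15-fold lower number from compound 1 to compound 2 (1.20 log units; beyond the scatter) and an at least 14-fold higher number from compound 2 to compound 3 (1.16 log units; beyond the scatter). The third step, a step that the two limits leave unreadable from compound 1 to compound 3, cannot be sized because both ends are limits.

Compound 4, `Cc1cc(C)c(Oc2cc(Nc3ccc(C#N)cc3)ncc2C(=O)NCc2cn(Cc3ccc(F)cc3)nn2)c(C)c1`, differs from compound 3 as follows: 4-fluorophenyl in place of 3-fluorophenyl on a saturated chain carbon bound to an aromatic nitrogen. The measured steps all exchange the whole group on the saturated chain carbon bound to the aromatic nitrogen for a different kind of group; none of them moves a substituent within the same ring, so they do not bear directly on this change. The two aryl-bearing compounds, compound 1 and compound 3, both sit at limits, and the difference to compound 4 is the smaller change. No step beyond the scatter is expected; the estimated step is an at least 1.0-fold lower number from compound 3 to compound 4 (0.00 log units; that floor lies within the scatter). Compound 4 is expected at 200000 nM, within 80000 nM to 300000 nM, most likely again reported as a limit.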

Compound 4, half-maximal cytotoxic concentration: >= 153000 nM
Compound 4: no number, only a limit (the forecaster's own chance of this, stated with the estimate: 70%); the middle value is on the limit's open side.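

Moving the fluorine within the ring, from 3-fluorophenyl to 4-fluorophenyl, is the first change here that keeps the group on the saturated chain carbon bound to an aromatic nitrogen and alters only its substitution, and in this assay compound 4 again ends in a limit and not a number: the limit of >= 153000 nM in this assay, at which 1 of the 4 values shown sits.

All three aryl-bearing compounds, compound 1, compound 3 and compound 4, now read as limits, and compound 2, with methoxycarbonyl, remains the one exception that gives a number. Exchanging methoxycarbonyl for 4-fluorophenyl gives an at least 11-fold higher number from compound 2 to compound 4 (1.04 log units; beyond the scatter), while the steps among the three limit compounds cannot be read.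

Whether the fluorine position changes the tolerated concentration at all stays open, as the limits give no size for any difference among these aryl compounds. Also open, from the compounds shown here alone, is whether the low reading of compound 2 belongs to the methoxycarbonyl group in particular, or whether a carboxylic acid, an amine or a longer chain on the same carbon would read as a number too.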